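A few compounds are considered here, and "the series" means these few. Any claim that something is new, unique, unknown or untested is made for them only; others in the source may bear on it.

In an ADME assay on Vero cells (Chlorocebus sabaeus) for cytotoxicity (on this read-out lower numbers stand for higher toxicity in this test and higher numbers for lower toxicity in this test), compound 1 `CC(=O)Nc1nc(N)nc2c1ncn2[C@H]1CO[C@@H](CO)O1` gives > 100000 nM as a limit. Compound 2 `CCCC(=O)Nc1nc(N)nc2c1ncn2[C@H]1CO[C@@H](CO)O1` gives > 100000 nM as a limit too, so its standing is known only as that limit. The change ethyl in place of hydrogen on a saturated chain carbon, three bonds along the chain from a carbonyl carbon puts ethyl in place of hydrogen on a saturated chain carbon, three bonds along the chain from a carbonyl carbon, and turns compound 2 into compound 3 `CCCCCC(=O)Nc1nc(N)nc2c1ncn2[C@H]1CO[C@@H](CO)O1` in one move. Going by the values given here, the only measured step of this kind is a step that the two limits leave unreadable from compound 1 to compound 2 and its size cannot be read, with the limit of > 100000 nM in this assay, at which 2 of the 2 values shown sit, as the sole evidence. No step beyond the scatter is therefore expected in this assay and no direction can be assigned. The expected step of a number no higher from compound 2 to compound 3 (the limit leaves the size open) is an estimate only. Compound 3 is estimated at 100000 nM with an expected range of 50000 nM to 200000 nM and a reading at the limit of the test is the likeliest outcome.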

Compound 3, half-maximal cytotoxic concentration: > 100000 nM
Compound 3 ended at the assay's limit (the forecaster's own chance of this, stated with the estimate: 85%); the middle value sits exactly at the limit.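

No step can be read among compound 1, compound 2 and compound 3 in this assay, since each value is a limit: the limit of > 100000 nM in this assay, at which 3 of the 3 values shown sit.

Where each true cytotoxic concentration lies, and whether chain length shifts it, remains open.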